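Replacing 4-phenylphenyl with 2-nitrophenyl on the shared core

A few compounds are considered here, and "the series" means these few. Any claim that something is new, unique, unknown or untested is made for them only; others in the source may bear on it.

For the measured compounds named here, in a functional assay with Homo sapiens as the target (a lower number here means a stronger inhibitor, a higher number a weaker inhibitor), three compounds with a shared core have numbers so far. Compound 1 `CC(C)[C@H](NC(=O)COc1cccc2ccccc12)C(=O)N[C@@H](CC(=O)O)C(=O)COC(=O)c1c(Cl)cccc1Cl` gives 11500 nM, compound 2 `CC(C)[C@H](NC(=O)COc1cccc2ccccc12)C(=O)N[C@@H](CC(=O)O)C(=O)COc1ccc(-c2ccccc2)cc1` gives 38700 nM and compound 3 `CC(C)[C@H](NC(=O)COc1cccc2ccccc12)C(=O)N[C@@H](CC(=O)O)C(=O)COc1ccc(Oc2ccc(C(F)(F)F)cc2)cc1` gives 24900 nM. Compound 2 stands at the high end of these numbers, within the scatter of compound 3, while compound 1 lies further off.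

Compound 4 `CC(C)[C@H](NC(=O)COc1cccc2ccccc12)C(=O)N[C@@H](CC(=O)O)C(=O)COc1ccccc1[N+](=O)[O-]` has not yet been measured. It differs from compound 2 as follows: 2-nitrophenyl in place of 4-phenylphenyl on an oxygen on a saturated carbon. Going by the values given here, two measured steps bear on this change, since both alter the group on that oxygen. One is a 3.4-fold higher number from compound 1 to compound 2 (0.53 log units; beyond the scatter), and the other is a 1.6-fold lower number from compound 2 to compound 3 (0.19 log units; within the scatter). Among the compounds with values here, neither is large, and no measured compound carries 2-nitrophenyl, so the data give no direction for this change. The expected result is therefore no large move, namely a 1.5-fold lower number from compound 2 to compound 4 (0.19 log units; within the scatter). For compound 4 the estimated value is 25000 nM, with an expected range of 9000 nM to 70000 nM.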

Compound 4, half-maximal inhibitory concentration: 27700 nM
Compound 4: the middle estimate sits 1.1-fold (0.04 log units) below what was measured; the measured number falls inside the stated range.
By their numbers in this assay, from the lowest: compound 1; then compounds 3, 4 and 2 (each within the scatter of the next).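

In this assay, the group on this oxygen could change considerably without a clear shift: a 1.4-fold lower number from compound 2 to compound 4 (0.15 log units; within the scatter), even though 2-nitrophenyl has one six-membered aromatic ring where 4-phenylphenyl has two, and two hydrogen-bond acceptors where 4-phenylphenyl has none. Compound 4 also sets a third aryl group beside those of compound 2 and compound 3, and these three compounds sit within the scatter of one another in an unbroken run. The separation from the (2,6-dichlorophenyl)carbonyl group holds as well, with a 2.4-fold higher number from compound 1 to compound 4 (0.38 log units; beyond the scatter), and nothing shown explains these results.

From the compounds shown here alone, it remains open whether an amine or a carboxylic acid on the phenyl ring in place of the nitro group would leave the number in this range. Going by these compounds, it is also open whether the lower number of compound 1 goes with the carbonyl or with the two chlorines, which a plain benzoyl group could separate.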